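Ethyl for chloro on the aryl ring of a shared core

The compounds below may be only part of what the source reports. "The series", "measured", "known", "first", "only" and "open" are said of these compounds alone.

Measured compounds:
compound 1, `CCCCN(CC)c1cc(C)nc2c1NC(=O)CN2c1ccc(Br)cc1Cl`, an assay on HEK-293T cells for displacement of a labelled ligand from corticotropin-releasing factor receptor 2 (Homo sapiens), read by scintillation counting, with a stated time of 2 h, tested at 1 uM; a higher number here means more inhibition at the concentration tested (going by the name of the read-out), a lower number less inhibition: "not determined" (no result reported)
compound 2, `CCCCN(CC)c1cc(C)nc2c1NC(=O)CN2c1ccc(OC)cc1C`, this assay: -2.3%

Compound 1 stands without a number in this assay. Compound 2, which shares the core, gives -2.3%, a read-out that sits within the scatter of zero. Compound 3, `CCCCN(CC)c1cc(C)nc2c1NC(=O)CN2c1ccc(Br)cc1CC`, differs from compound 1 by ethyl in place of chloro on an aromatic carbon. Within the data shown here, no measured pair shows the size of such a step, so its direction is unknown; the account expects a read-out for compound 3 near the scatter, given that compound 2 gives -2.3%. For compound 3 the estimate is 5%, expected between -10% and 25%.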

Compound 3, a percentage reported as inhibition, at one concentration (the size of the read-out at that concentration, not a potency): 2.1%
The estimate for compound 3 lay 2.9 percentage points above the measured number; measured number inside the range.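

With ethyl on this aromatic carbon, compound 3 gives 2.1% in this assay, so this bromo-bearing aryl group with ethyl shows no clear inhibition at the concentration tested. The read-out is a number 4.4 percentage points higher from compound 2 to compound 3 (within the scatter), so the 4-bromo-2-ethylphenyl and 4-methoxy-2-methylphenyl groups cannot be told apart here. No measurement on hand explains these read-outs.

The step from chloro to ethyl cannot be read, since compound 1 has no number. Going by these compounds, whether a longer chain such as butyl, or an amine, at this position would give a read-out beyond the scatter remains open.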